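From carbamoyl to methanesulfonamido on the shared core

This account rests on a few compounds, and the source may have more. Where it says the series, first, only, none or still open, it means among the compounds named here.

Compound 1 `CS(=O)(=O)Nc1ccc(S(=O)(=O)Nc2cccc3c(C#N)c[nH]c23)cc1` gives 3.5 ug/mL
Compound 2 `N#Cc1ccc(S(=O)(=O)Nc2cccc3c(Cl)c[nH]c23)cc1` gives 1.4 ug/mL
Compound 3 `NC(=O)c1ccc(S(=O)(=O)Nc2cccc3c(Cl)c[nH]c23)cc1` gives 0.87 ug/mL

In a functional assay on P388 cells (Mus musculus) for antiproliferative activity (on this read-out lower numbers stand for stronger inhibition and higher numbers for weaker inhibition), compound 3 reads 0.87 ug/mL and sits within the scatter of compound 2 at 1.4 ug/mL while compound 1 lies clearly higher at 3.5 ug/mL on this scale. Compound 4 `CS(=O)(=O)Nc1ccc(S(=O)(=O)Nc2cccc3c(Cl)c[nH]c23)cc1` keeps the core of compound 3 and takes methanesulfonamido in place of carbamoyl on an aromatic carbon. Among the compounds with values here, one measured step touches this same place: it is a 1.6-fold lower number from compound 2 to compound 3 (0.21 log units; within the scatter) for carbamoyl in place of cyano, and it stays within the scatter. Within the data shown here, compound 1 at 3.5 ug/mL also carries methanesulfonamido, but on a different core, so no measured pair isolates that group. A small rise in the number, not beyond the scatter, is therefore expected, and the estimated change is a 1.4-fold higher number from compound 3 to compound 4 (0.14 log units; within the scatter) in this assay on this basis. For compound 4 the estimated value is 1.2 ug/mL with an expected range from 0.4 ug/mL to 3.5 ug/mL in this measurement.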

Compound 4, half-maximal inhibitory concentration: 1.6 ug/mL
Beside the measured number, compound 4's estimate is 1.3-fold (0.12 log units) below it; the range from low to high includes it.
By their numbers in this assay, from the lowest: compounds 3, 2 and 4 (each within the scatter of the next); then compound 1.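

In this assay, methanesulfonamido on the aromatic carbon para to a large group gives a 1.8-fold higher number from compound 3 to compound 4 (0.26 log units; within the scatter) against carbamoyl and a 1.1-fold higher number from compound 2 to compound 4 (0.06 log units; within the scatter) against cyano, so the read-out does not separate these three groups at this position. Within the data shown here, with methanesulfonamido held fixed, chloro in place of cyano on the shared core gives a 2.2-fold lower number from compound 1 to compound 4 (0.34 log units; beyond the scatter) and is the only one of these steps beyond the scatter, which places the clearer difference at that other position rather than at this one. No evidence is available to explain these numbers.

From the compounds shown here alone, whether an amine or a carboxylic acid at this position would also stay within the scatter remains open. So does whether chloro in place of cyano on the core gives a similar step alongside carbamoyl.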